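This account rests on a few compounds, and the source may have more. Where it says the series, first, only, none or still open, it means among the compounds named here.

Measured so far, in a functional assay on HeLa cells (Homo sapiens) for antiproliferative activity, read by sulforhodamine B assay, with a stated time of 48 h; on this read-out higher numbers stand for weaker inhibition and lower numbers for stronger inhibition:

Compound 1, `COc1cc(OC)c2sc(-c3ccc(N/C=C\C(=O)c4ccc(OC)c(O)c4)cc3)nc2c1`, gives 12100 nM.
Compound 2, `COc1cc(OC)c2sc(-c3ccc(N/C=C\C(=O)c4ccc(OC)c([N+](=O)[O-])c4)cc3)nc2c1`, gives 12900 nM.
Compound 3, `COc1ccc2nc(-c3ccc(N/C=C\C(=O)c4ccc(OC)c(O)c4)cc3)sc2c1`, gives 6900 nM.

Compound 2 differs from compound 1 by one change, (nitro in place of hydroxy on an aromatic carbon), and this change made a step of a 1.1-fold higher number from compound 1 to compound 2 (0.03 log units; within the scatter). Compound 3 carries a different core from compound 1; the difference between the two cores is not broken down here. Within the data shown here, compound 4, `COc1ccc2nc(-c3ccc(N/C=C\C(=O)c4ccc(OC)c([N+](=O)[O-])c4)cc3)sc2c1`, which still awaits measurement, differs from compound 3 by nitro in place of hydroxy on an aromatic carbon, the same change at the same place, so the step from compound 1 to compound 2 is the only guide. Because that earlier step, a 1.1-fold higher number from compound 1 to compound 2 (0.03 log units; within the scatter), stayed within the scatter, a step of about a 1.1-fold higher number from compound 3 to compound 4 (0.04 log units; within the scatter) is expected. On that basis compound 4 is estimated at 7500 nM, most likely between 4000 nM and 15000 nM.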

Compound 4, half-maximal inhibitory concentration: 17600 nM
The estimate for compound 4 lay 2.3-fold (0.37 log units) below the measured number; the measured number lies above the stated range.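

In this assay, putting nitro in place of hydroxy gave a 2.6-fold higher number from compound 3 to compound 4 (0.41 log units; beyond the scatter), a modest step, while the same swap on the other core stayed within the scatter. Set side by side, the two steps are no further apart than two such steps can be by chance: the same change on two cores in this assay, a 1.1-fold higher number (0.03 log units; within the scatter) from compound 1 to compound 2 and a 2.6-fold higher number (0.41 log units; beyond the scatter) from compound 3 to compound 4, 2.4-fold (0.38 log units) apart, within the scatter of two such steps. The swap can therefore be treated as carrying across these two cores about equally, although two pairs cannot prove that it does, nor rule out a small influence of the core.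

The compounds shown leave open how an amine or a carboxylic acid in place of the hydroxy would behave. They also leave open whether this swap behaves the same way on any further core.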